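The compounds below may be only part of what the source reports. "The series", "measured", "known", "first", "only" and "open" are said of these compounds alone.

Measured so far in a functional assay on U-373MG ATCC cells for inhibition, with U373 MG (Homo sapiens) as the target, read by MTT assay, with a stated time of 7 days; on this read-out higher numbers stand for weaker inhibition of growth and lower numbers for stronger inhibition of growth:
compound 1 `NC(=O)c1ncn2c(=O)n(Cc3cccs3)nnc12` gives > 50000 nM, a limit of this assay.
compound 2 `NC(=O)c1ncn2c(=O)n(Cc3ccsc3)nnc12` gives > 50000 nM, a limit.
compound 3 `NC(=O)c1nc[nH]c1N/N=N/Cc1cccs1` gives > 50000 nM, a limit.

All three values sit at the limit of > 50000 nM in this assay, at which 3 of the 3 values shown sit, so no ordering among them can be read. The change from compound 1 to compound 2, (thiophen-3-yl in place of thiophen-2-yl on a saturated chain carbon bound to an aromatic nitrogen), gives a step that the two limits leave unreadable from compound 1 to compound 2. The difference between the core of compound 1 and the core of compound 3 is not broken down here.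

Compound 4 `NC(=O)c1nc[nH]c1N/N=N/Cc1ccsc1` is not yet measured. It carries thiophen-3-yl in place of thiophen-2-yl on a saturated chain carbon bound to a double-bonded nitrogen, the same kind of change as from compound 1 to compound 2, though there the place was a saturated chain carbon bound to an aromatic nitrogen, here a saturated chain carbon bound to a double-bonded nitrogen. Since compound 3 shows only > 50000 nM, the step from compound 3 to compound 4 is expected as a step that the limit leaves unreadable from compound 3 to compound 4, most likely again ending at a limit. Compound 4 is therefore estimated at 80000 nM, between 30000 nM and 300000 nM.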

Compound 4, concentration for 50% growth inhibition: > 50000 nM
Compound 4: a limit, no number (the forecaster's own chance of this, stated with the estimate: 85%); the middle value is on the limit's open side.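

Compound 4 also ends at a limit, so no step can be read from compound 3 to compound 4: the limit of > 50000 nM in this assay, at which 4 of the 4 values shown sit. The compounds shown leave open whether thiophen-3-yl and thiophen-2-yl differ at all in this assay.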